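This account rests on a few compounds, and the source may have more. Where it says the series, first, only, none or still open, it means among the compounds named here.

Measured so far:
compound 1, `COc1ccccc1Nc1nnc(Nc2nc(-c3ccc(Cl)cc3)cs2)s1`, 100 mg/kg
compound 2, `Cc1ccc(Nc2nnc(Nc3nc(-c4ccc(Br)cc4)cs3)s2)cc1`, 300 mg/kg

In a functional assay on the whole organism (strain albino) with Mus musculus as the target, with a stated time of 4 h (on this read-out lower numbers stand for an effect already at smaller amounts and higher numbers for an effect only at larger amounts of compound), compound 2 gives 300 mg/kg, the highest of the two numbers; compound 1 gives 100 mg/kg, a lower number, beyond the scatter. Compound 3, `COc1ccccc1Nc1nnc(Nc2nc(-c3ccc(Br)cc3)cs2)s1`, follows from compound 2 by 2-methoxyphenyl in place of 4-methylphenyl on a nitrogen on an aromatic ring. Within the data shown here, no step between measured compounds covers this change; compound 1 carries the 2-methoxyphenyl group and shows the lower number. The expected step, a 2.0-fold lower number from compound 2 to compound 3 (0.30 log units; within the scatter), goes toward a lower number and lies around the edge of the scatter. Compound 3 is estimated at 150 mg/kg, with a range from 70 mg/kg to 300 mg/kg.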

Compound 3, minimum effective dose: 300 mg/kg
Compound 3: the middle estimate sits 2.0-fold (0.30 log units) below what was measured; the range from low to high includes it.
By their numbers in this assay, from the lowest: compound 1; then compounds 2 and 3 (each within the scatter of the next).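

In this assay, 2-methoxyphenyl in place of 4-methylphenyl on a nitrogen on an aromatic ring, with the bromo group held, gives no change at the digits printed from compound 2 to compound 3 (within the scatter) so this change does not register here. With 2-methoxyphenyl held, bromo in place of chloro on an aromatic carbon gives a 3.0-fold higher number from compound 1 to compound 3 (0.48 log units; beyond the scatter) so the lower number of compound 1 goes with chloro, not with 2-methoxyphenyl. No supporting data bear on either step.

Open, going by these compounds, is whether chloro with 4-methylphenyl repeats this step, and how a carboxylic acid or a longer alkyl chain on that nitrogen would read.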